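The source may report more compounds than this note shows. Statements on the series, on what has been measured and on what is new or still open speak of the compounds shown alone.

Measured so far:
- compound 1, `CCCCCCCCCCCCCCCCCCNC(=O)[C@@H](N)[C@@H](C)O`: 44500 nM
- compound 2, `CCCCCCCCCCCCCCNC(=O)[C@@H](NC(=O)c1ccccc1)[C@@H](C)O`: 54200 nM

Both numbers come from a functional assay on HepG2 cells (Homo sapiens) for cytotoxicity, read by MTT assay, with a stated time of 48 h; on this read-out lower numbers stand for stronger inhibition and higher numbers for weaker inhibition. Among the compounds with values here, compound 2 gives the higher of the two, yet its only neighbour, compound 1, sits within the scatter of it, so no order can be read between them. Compound 3, `CCCCCCCCCCCCCCCCCCNC(=O)[C@@H](NC(=O)c1ccccc1)[C@@H](C)O`, differs from compound 2 by butyl in place of hydrogen on a saturated chain carbon, ten or more bonds along the chain from an amide-type nitrogen. Within the data shown here, no measured pair isolates this change. Given how close the two known values lie, the analyst expects a step of a 1.1-fold lower number from compound 2 to compound 3 (0.04 log units; within the scatter) in this assay, none beyond the scatter. Compound 3 is therefore estimated at 50000 nM, with a range from 20000 nM to 125000 nM.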

Compound 3, half-maximal inhibitory concentration: > 400000 nM
Compound 3 was reported as a limit; the forecaster's own chance of this, stated with the estimate: 10%; at least 8.0-fold (0.90 log units) between middle value and limit.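

In this assay compound 3 gives > 400000 nM, which is a limit of the assay and not a number. Butyl in place of hydrogen on a saturated chain carbon moves the read-out beyond the scatter, with an at least 7.3-fold higher number from compound 2 to compound 3 (0.86 log units; beyond the scatter). Benzoyl in place of hydrogen on an amine nitrogen does so too, with an at least 8.9-fold higher number from compound 1 to compound 3 (0.95 log units; beyond the scatter), and the true size of both steps stays unknown.

As far as these compounds go, whether butyl on the chain has the same effect with a free amine remains open. So does whether acetyl in place of benzoyl would match the benzoyl step.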